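The compounds below may be only part of what the source reports. "The series", "measured", "known", "first", "only" and "open" are said of these compounds alone.

Compound 1 `Cc1cc(-c2ccccc2)cc(C)c1S(=O)(=O)[C@@H](CNC(=O)C1=NOC2(CCC(CNc3ncc[nH]3)CC2)C1)C(=O)O` gives 670 nM in a functional assay for antagonist activity at integrin alpha-5/beta-1 (Homo sapiens), read by ELISA; on this read-out higher numbers stand for weaker inhibition and lower numbers for stronger inhibition.
Compound 2 `O=C(NC[C@@H](C(=O)O)S(=O)(=O)c1ccccc1)C1=NOC2(CCC(CNc3ncc[nH]3)CC2)C1` gives 4700 nM in this assay.
Compound 3 `Cc1cc(C)c(S(=O)(=O)[C@@H](CNC(=O)C2=NOC3(CCC(CNc4ncc[nH]4)CC3)C2)C(=O)O)c(C)c1` gives 1500 nM in this assay.

All three compounds share one core and differ only in the aromatic ring attached to the sulfonyl group. On the numbers shown, compound 3 holds the middle place of three: it is reached by a 2.2-fold higher number from compound 1 to compound 3 (0.35 log units; beyond the scatter) and by a 3.1-fold lower number from compound 2 to compound 3 (0.50 log units; beyond the scatter), both steps beyond the scatter but modest in size.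

Compound 4 `Cc1cccc(C)c1S(=O)(=O)[C@@H](CNC(=O)C1=NOC2(CCC(CNc3ncc[nH]3)CC2)C1)C(=O)O` has not yet been measured. It differs from compound 3 in one place: hydrogen in place of methyl on an aromatic carbon. This change strips one of the three methyl groups of compound 3 and so moves its ring partway back toward the bare phenyl ring of compound 2. The step that bears on it most directly is a 3.1-fold lower number from compound 2 to compound 3 (0.50 log units; beyond the scatter), which shows that adding all three methyl groups gave a lower number. Removing one of them is expected to give back a part of that difference, so a small rise in the number is expected, possibly no larger than the scatter. Compound 4 is therefore estimated at 2200 nM, with a range from 1000 nM to 5000 nM. The expected step is a 1.5-fold higher number from compound 3 to compound 4 (0.17 log units; within the scatter).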

Compound 4, half-maximal inhibitory concentration: 1800 nM
Compound 4: middle estimate off by 1.2-fold (0.09 log units), on the high side, and the stated range covers the measured number.
By their numbers in this assay, from the lowest: compound 1; then compounds 3 and 4 (each within the scatter of the next); then compound 2.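

Removing the methyl group para to a large group changes little in this assay: the result is a 1.2-fold higher number from compound 3 to compound 4 (0.08 log units; within the scatter), so compound 3 and compound 4 cannot be told apart at this position. The earlier compounds shown here showed only that the full 2,4,6-trimethylphenyl ring gave a lower number than phenyl, whereas this result shows that the 2,6-dimethylphenyl ring, without the third methyl group, also does so, with a 2.6-fold lower number from compound 2 to compound 4 (0.42 log units; beyond the scatter). The same position is still able to register a change, since a phenyl group there separates the two compounds, with a 2.7-fold higher number from compound 1 to compound 4 (0.43 log units; beyond the scatter), and on these numbers hydrogen and methyl sit together while phenyl stands apart from both.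

The data shown give no explanation for this pattern. Still open, going by these compounds, is how a methoxy group, a chlorine atom or an ethyl group at this position would compare with hydrogen and phenyl, and whether a ring carrying just one methyl group would keep the lower number seen with the 2,6-dimethylphenyl ring.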